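The source may hold more compounds than are shown below. What is called first, only, known or untested is meant among the compounds shown, and "the series" means these compounds.

In a functional assay on MGC-803 cells (Homo sapiens) for inhibition, read by MTT assay, with a stated time of 72 h (a lower number here means a stronger inhibitor, a higher number a weaker inhibitor), compound 2 `N#Cc1c(Nc2ccccc2Cl)nc(SCc2cn(Cc3ccccc3Cl)nn2)nc1-c1ccccc1` gives 4640 nM. Among the two compounds measured, that is the only actual number recorded in this assay. Compound 1 `C#CCSc1nc(Nc2cccc(C(F)(F)F)c2)c(C#N)c(-c2ccccc2)n1` reaches only a limit of this assay, > 128000 nM. Compound 3 `N#Cc1c(Nc2ccc(F)cc2)nc(SCc2cn(Cc3ccccc3Cl)nn2)nc1-c1ccccc1` has not yet been measured. It differs from compound 2 in one place: 4-fluorophenyl in place of 2-chlorophenyl on a nitrogen on an aromatic ring. For the measured compounds named here, no step between measured compounds carries this same change, so its effect in this assay cannot be read from the data at hand. The step expected in this assay is a 1.1-fold higher number from compound 2 to compound 3 (0.03 log units; within the scatter), a shift that is not expected to go beyond the usual scatter in either direction. For compound 3 the estimated value in this assay is 5000 nM, with a range expected to run from 1500 nM to 16000 nM.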

Compound 3, half-maximal inhibitory concentration: 8740 nM
The estimate for compound 3 lay 1.7-fold (0.24 log units) below the measured number, and the stated range covers the measured number.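

In this assay, for the compounds shown here, the change of 2-chlorophenyl to 4-fluorophenyl on the nitrogen gives the first reading of a step at this position, and that step stays within the scatter: a 1.9-fold higher number from compound 2 to compound 3 (0.27 log units; within the scatter). Between these two compounds, then, the assay does not separate the two substituted phenyl groups, even though both the halogen and its printed ring position change at once. No measurement at hand bears on why the step has this size.

Because both halogen and ring position change in this single step, the compounds shown leave open what each change does alone. They also leave open whether this nitrogen would keep a similar reading with a carboxylic acid or an amine on the phenyl ring, or with a plain unsubstituted phenyl.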